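Extending the acyl group on compound 2 from formyl to propanoyl

The source may hold more compounds than are shown below. What is called first, only, known or untested is meant among the compounds shown, and "the series" means these compounds.

Of the compounds shown here, three built on the same core have been tested in a functional assay on the whole organism (strain Wistar) for inhibition, with Rattus norvegicus as the target, read by paw edema, with stated times of 30 min and 60 min, at a dose of 50 mg/kg by the oral route; a lower number here means less inhibition, a higher number more inhibition at the dose given (going by the name of the read-out). Compound 1 `Cc1ccc(C2=NN(c3ccc([N+](=O)[O-])cc3)C(c3cn(-c4ccccc4)nc3-c3ccc(Cl)c(Cl)c3)C2)cc1` gives 72.5%. Compound 2 `O=CN1N=C(c2ccc(F)cc2)CC1c1cn(-c2ccccc2)nc1-c1ccc(Cl)c(Cl)c1` gives 56.5%, which places it second highest of the three numbers. Compound 3 `O=CN1N=C(c2ccc(Cl)cc2)CC1c1cn(-c2ccccc2)nc1-c1ccc(Cl)c(Cl)c1` gives 51.1%. Among the compounds with values here, the single step between compounds that differ in one place, chloro in place of fluoro on an aromatic carbon, is a number 5.4 percentage points lower from compound 2 to compound 3 (within the scatter). Compound 1 differs from compound 2 in more than one place, so its value only shows that its number lies higher than that of compound 2.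

The next compound, compound 4 `CCC(=O)N1N=C(c2ccc(F)cc2)CC1c1cn(-c2ccccc2)nc1-c1ccc(Cl)c(Cl)c1`, is reached from compound 2 by the change (ethyl in place of hydrogen on a carbonyl carbon). Within the data shown here, no measured step touches the carbonyl carbon, so nothing among the measured compounds bears directly on this change; the one step that exists, from fluoro to chloro, sits elsewhere and stayed within the scatter. In this assay, therefore, no step beyond the scatter is expected from compound 2 to compound 4, the expected change being a number 1.5 percentage points lower from compound 2 to compound 4 (within the scatter). Compound 4 is estimated to give 55%, with a range from 40% to 70%.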

Compound 4, a percentage reported as inhibition, in the whole organism at one dose (the size of the read-out at that dose, not a potency): 63.4%
The estimate for compound 4 lay 8.4 percentage points below the measured number, and the stated range covers the measured number.
By their numbers in this assay, from the lowest: compounds 3, 2, 4 and 1 (each within the scatter of the next, the first and the last beyond it).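

Within the data shown here, compound 4 supplies the first measured step at the carbonyl carbon: in this assay, going from formyl to propanoyl gives a number 6.9 percentage points higher from compound 2 to compound 4 (within the scatter). At this place, on a carbonyl carbon whose other neighbour is an amide-type nitrogen in a ring, ethyl in place of hydrogen adds 2 heavy atoms and no ring, yet the step cannot be told apart from the scatter of repeated measurements, so this position accepts the ethyl without a clear change in the read-out at the dose given. Nothing shown here offers an explanation of this result, and the data can only report the size of the step.

On these data alone, it remains open whether a longer chain than ethyl, a phenyl ring or an amine on the carbonyl carbon would produce a step beyond the scatter. As far as these compounds go, it is also open whether the ethyl step would look the same in a compound carrying chloro in place of fluoro on the aromatic carbon, as propanoyl appears here only together with fluoro.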